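A few compounds are considered here, and "the series" means these few. Any claim that something is new, unique, unknown or untested is made for them only; others in the source may bear on it.

Of the compounds shown here, three from this series have been tested in an ADME assay on Vero cells (Chlorocebus sabaeus) for cytotoxicity, read by resazurin assay, with a stated time of 2 days; on this read-out higher numbers stand for lower toxicity in this test and lower numbers for higher toxicity in this test. Compound 1, `CC(=O)OC[C@H]1O[C@@H](CC(=O)/C=C/c2cccc(NS(=O)(=O)c3ccc(C)cc3)c2)[C@H](OC(C)=O)[C@@H](OC(C)=O)[C@@H]1OC(C)=O`, gives 584000 nM in this assay, the highest number of the three. Compound 2, `O=C(/C=C/c1cccc(NC(=S)Nc2ccccc2)c1)C[C@@H]1OC[C@@H](O)[C@H](O)[C@H]1O`, gives 289000 nM, and compound 3, `Cc1ccc(S(=O)(=O)Nc2cccc(/C=C/C(=O)C[C@@H]3OC[C@@H](O)[C@H](O)[C@H]3O)c2)cc1`, gives 94700 nM, the lowest of the three.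

Compounds 3 and 2 share the same core and differ in one place: a group of 9 heavy atoms (7 carbon, 1 nitrogen, 1 sulfur; one six-membered aromatic ring of carbon only) in place of a group of 10 heavy atoms (7 carbon, 2 oxygen, 1 sulfur; one six-membered aromatic ring of carbon only), on a nitrogen on an aromatic ring. That change gives a 3.1-fold higher number from compound 3 to compound 2 (0.48 log units; beyond the scatter), so compound 2 is the less toxic of the pair in this assay.

Compound 4, `CC(=O)OC[C@H]1O[C@@H](CC(=O)/C=C/c2cccc(NC(=S)Nc3ccccc3)c2)[C@H](OC(C)=O)[C@@H](OC(C)=O)[C@@H]1OC(C)=O`, has not yet been measured. It stands to compound 1 as compound 2 stands to compound 3: a group of 9 heavy atoms (7 carbon, 1 nitrogen, 1 sulfur; one six-membered aromatic ring of carbon only) in place of a group of 10 heavy atoms (7 carbon, 2 oxygen, 1 sulfur; one six-membered aromatic ring of carbon only), on a nitrogen on an aromatic ring. The place of the change is the same in both pairs, so this is the same change made on a different core. Compound 1 and compound 3 have different cores, and the difference between the two cores is not broken down here; their values simply show that compound 1 is the less toxic of the two in this assay.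

Compound 4 is expected to move by a 2.6-fold higher number from compound 1 to compound 4 (0.41 log units; beyond the scatter), a step of about the size seen from compound 3 to compound 2, because that earlier change gave a 3.1-fold higher number from compound 3 to compound 2 (0.48 log units; beyond the scatter). Starting from the high number of compound 1, 584000 nM, compound 4 is therefore estimated at 1500000 nM, with a likely range from 600000 nM to 3500000 nM.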

Compound 4, half-maximal cytotoxic concentration: 337000 nM
For compound 4 the middle estimate is 4.5-fold (0.65 log units) above the measured one; the measured number lies below the stated range.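

In this assay, replacing the (4-methylphenyl)sulfonyl group on the nitrogen with the group of 9 heavy atoms gives a 1.7-fold lower number from compound 1 to compound 4 (0.24 log units; within the scatter), so on this core the swap produces no difference that can be told apart from the ordinary variation between repeat measurements. Among these compounds, the same swap on the other core gave a clear step, so its size in this assay does not carry over unchanged from one core to the other: the same change on two cores in this assay, a 3.1-fold higher number (0.48 log units; beyond the scatter) from compound 3 to compound 2 and a 1.7-fold lower number (0.24 log units; within the scatter) from compound 1 to compound 4, 5.3-fold (0.72 log units) apart, beyond the scatter of two such steps This rests on only one pair of compounds per core, so it shows that the core can matter for this change, but not which part of the core is responsible, why the two results part, or what the change would do on a third core.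

The compounds shown leave open how the two cores would respond to other groups on the same nitrogen, such as a simple amide or a urea with oxygen in place of sulfur. They also leave open whether a core carrying only some of the acetate esters of compound 1 would follow compound 1 or compound 3 in its response to this change.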